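Phenyl-tetrazolyl acetamide series, Kir3.1/Kir3.2 activation notes

This account rests on a few compounds, and the source may have more. Where it says the series, first, only, none or still open, it means among the compounds named here.

Measured compounds:
compound 1 `O=C(Cn1nnc(-c2ccccc2)n1)NC1CC2CCC1C2` — 1980 nM
compound 2 `Cc1cc(NC(=O)Cn2nnc(-c3ccccc3)n2)n(C2CCC(C)(C)CC2)n1` — > 221 nM (a limit)

In an assay on HEK293 cells for activation of Kir3.1/Kir3.2 (Homo sapiens), read by thallium flux (on this read-out lower numbers stand for an effect already at smaller amounts and higher numbers for an effect only at larger amounts of compound), compound 1 gives 1980 nM. Compound 2 gives only a limit in this assay, > 221 nM, and the entry the limit of > 221 nM in this assay, at which 1 of the 2 values shown sits, shows that no number beyond the limit is available for compound 2. Compound 3 `Cc1cc(NC(=O)Cn2nnc(-c3ccccc3)n2)n(-c2ccccc2)n1` differs from compound 2 by phenyl in place of 4,4-dimethylcyclohexyl on an aromatic nitrogen. Going by the values given here, no step between measured compounds is known, so this change is untested; a modest shift in either direction, or none beyond the scatter, is expected. Compound 3 is estimated at 3000 nM (700 nM to 15000 nM). The expected step is a step that the limit leaves unreadable from compound 2 to compound 3.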

Compound 3, half-maximal effective concentration: 3020 nM
Compound 3: middle estimate off by 1.0-fold (0.00 log units), on the low side; the range from low to high includes it.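

No step from compound 2 to compound 3 can be read, since compound 2 stands only as a limit: the limit of > 221 nM in this assay, at which 1 of the 3 values shown sits.

As far as these compounds go, whether phenyl or 4,4-dimethylcyclohexyl on the aromatic nitrogen gives the lower value, and by how much, stays open.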